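Replacing the nitro group of compound 3

This account rests on a few compounds, and the source may have more. Where it says the series, first, only, none or still open, it means among the compounds named here.

In a functional assay on MDA-MB-468 cells (Homo sapiens) for antiproliferative activity, read by MTT assay, with a stated time of 72 h (a higher number here means a weaker inhibitor, a lower number a stronger inhibitor), compound 3 (`COc1ccc(NC(=O)c2cc(OC)c(OC)c(OC)c2)cc1[N+](=O)[O-]`) gives 2900 nM and sits between the other two measured compounds. Compound 1 (`COc1cc(-c2nccn2-c2ccc(C)cc2)cc(OC)c1OC`) stands lower at 400 nM and compound 2 (`COc1cc(-c2nccn2-c2cccc(C)c2)cc(OC)c1OC`) higher at 22600 nM on this scale. Compound 4 (`COc1ccc(NC(=O)c2cc(OC)c(OC)c(OC)c2)cc1N`) carries amino in place of nitro on an aromatic carbon ortho to a methoxy group (amino in place of nitro on an aromatic carbon). Among the compounds with values here, the one measured step (a 57-fold higher number from compound 1 to compound 2 (1.75 log units; beyond the scatter)) places 3-methylphenyl in place of 4-methylphenyl on an aromatic nitrogen. It shows that a single change can be large in this assay yet gives no direction here. Within the data shown here, no measured pair covers nitro and amino, so only a moderate move to a lower number is expected. The expected step (a 2.4-fold lower number from compound 3 to compound 4 (0.38 log units; beyond the scatter)) may stay close to the scatter. Compound 4 is estimated at 1200 nM with an expected range of 250 nM to 6000 nM in this measurement.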

Compound 4, half-maximal inhibitory concentration: 2000 nM
Beside the measured number, compound 4's estimate is 1.7-fold (0.22 log units) below it, and the stated range covers the measured number.
By their numbers in this assay, from the lowest: compound 1; then compounds 4 and 3 (each within the scatter of the next); then compound 2.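

In this assay, amino in place of nitro on an aromatic carbon, ortho to a methoxy group, gives a 1.5-fold lower number from compound 3 to compound 4 (0.16 log units; within the scatter) and so leaves the number unchanged within the scatter. At this position, the loss of three heavy atoms and the entry of one, with a hydrogen-bond donor gained, thus brings no measurable shift. Nothing available explains this result. On these data alone, whether a hydroxyl or an acetamide group at the same place would also leave the number unchanged stays open. The compounds shown also do not tell whether this change would act alike on the core of compound 1.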